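A few compounds are considered here, and "the series" means these few. Any claim that something is new, unique, unknown or untested is made for them only; others in the source may bear on it.

For the measured compounds named here, in a functional assay on PC-3 cells (Homo sapiens) for antiproliferative activity, read by MTT assay, with a stated time of 48 h (a higher number here means a weaker inhibitor, a lower number a stronger inhibitor), compound 2 `Cc1ccc(NC(=O)Nc2nnc(Sc3ncnc4scc(-c5ccncc5)c34)s2)cc1Cl` gives 4700 nM, the second highest of the three numbers so far: compound 1 `O=C(Nc1cccc(C(F)(F)F)c1)Nc1nnc(Sc2ncnc3scc(-c4ccncc4)c23)s1` gives 11500 nM and compound 3 `O=C(Nc1ccc(F)cc1)Nc1nnc(Sc2ncnc3scc(-c4ccncc4)c23)s1` gives 970 nM. Compound 4 `O=C(Nc1ccc(Cl)c(Cl)c1)Nc1nnc(Sc2ncnc3scc(-c4ccncc4)c23)s1` differs from compound 2 by chloro in place of methyl on an aromatic carbon. Going by the values given here, no measured step swaps a chloro for a methyl; the three measured steps each exchange the whole aryl group on an amide-type nitrogen: a 2.4-fold lower number from compound 1 to compound 2 (0.39 log units; beyond the scatter), a 12-fold lower number from compound 1 to compound 3 (1.07 log units; beyond the scatter) and a 4.8-fold lower number from compound 2 to compound 3 (0.69 log units; beyond the scatter). They show that this aryl group shifts the numbers well beyond the scatter, but they give no direction for this single swap. From compound 2 the expected step is therefore small: a 1.3-fold lower number from compound 2 to compound 4 (0.13 log units; within the scatter). Compound 4 is expected to give about 3500 nM, somewhere between 1200 nM and 10000 nM.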

Compound 4, half-maximal inhibitory concentration: 3600 nM
Beside the measured number, compound 4's estimate is 1.0-fold (0.01 log units) below it; the range from low to high includes it.
By their numbers in this assay, from the lowest: compound 3; then compounds 4 and 2 (each within the scatter of the next); then compound 1.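

Exchanging only the methyl of the 3-chloro-4-methylphenyl group for chloro, ortho to a chloro group, gives a 1.3-fold lower number from compound 2 to compound 4 (0.12 log units; within the scatter) and so leaves the two groups indistinguishable at this position. Changing the whole aryl group still matters, with a 3.2-fold lower number from compound 1 to compound 4 (0.50 log units; beyond the scatter) and a 3.7-fold higher number from compound 3 to compound 4 (0.57 log units; beyond the scatter) showing that the 3,4-dichlorophenyl group falls within the range set by the earlier groups. Nothing available explains any of these steps. What the compounds shown leave open is how a different group at this position, such as an amine or a carboxylic acid, would change the number.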